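The source may report more compounds than this note shows. Statements on the series, on what has been measured and on what is new or still open speak of the compounds shown alone.

Measured compounds, all in a functional assay on HCT-116 cells (Homo sapiens) for cytotoxicity; a higher number here means a weaker inhibitor, a lower number a stronger inhibitor:
- compound 1, `COc1ccc(C2=C(c3cccs3)C(=O)N3CCCC3C2)cc1`: 5000 nM
- compound 2, `COc1ccc(C2=C(c3ccco3)C(=O)N3CCCC3C2)cc1`: 6000 nM
- compound 3, `COc1ccc(C2=C(c3ccoc3)C(=O)N3CCCC3C2)cc1`: 3000 nM

The three share one core and differ only in the five-membered aromatic ring on the double-bonded ring carbon. None of the three numbers is separated from another beyond the scatter: a 1.2-fold higher number from compound 1 to compound 2 (0.08 log units; within the scatter), a 1.7-fold lower number from compound 1 to compound 3 (0.22 log units; within the scatter), a 2.0-fold lower number from compound 2 to compound 3 (0.30 log units; within the scatter). Compound 3 therefore stands among values that cannot be told apart on the data, and no ordering of the three is supported.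

Compound 4, `CSc1ccc(C2=C(c3ccoc3)C(=O)N3CCCC3C2)cc1`, is not yet measured. It keeps the furan-3-yl of compound 3 and changes the substituent on the six-membered ring: methylsulfanyl in place of methoxy on an aromatic carbon. Among the compounds with values here, no measured step touches this part of the structure; every step in hand concerns the five-membered ring, so nothing speaks directly to the size or direction of this change. In the absence of a relevant precedent, and given that three variations elsewhere on the core all stayed within the scatter, the working expectation for this assay is no step beyond the scatter. Compound 4 is accordingly expected near the number of compound 3, at 3000 nM, with a range of 1000 nM to 9000 nM, which corresponds to an expected step of no change at the digits printed from compound 3 to compound 4 (within the scatter).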

Compound 4, half-maximal inhibitory concentration: 1100 nM
Compound 4: middle estimate off by 2.7-fold (0.44 log units), on the high side; the range from low to high includes it.
By their numbers in this assay, from the lowest: compound 4; then compounds 3, 1 and 2 (each within the scatter of the next).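

In this assay, within the data shown here, methylsulfanyl in place of methoxy on an aromatic carbon para to a large group gives a 2.7-fold lower number from compound 3 to compound 4 (0.44 log units; beyond the scatter) and this is the only step that lies beyond the scatter. The substituent at this position therefore registers in the read-out, whereas the three exchanges of the five-membered aromatic ring in compounds 1, 2 and 3 could not be told apart, although this step is modest and rests on a single matched pair carrying furan-3-yl. No measurement accompanies the result that would explain why the exchange of oxygen for sulfur at this position goes with a lower number.

Still open, from the compounds shown here alone, is whether methylsulfanyl gives a similar step when the double-bonded ring carbon carries thiophen-2-yl or furan-2-yl instead of furan-3-yl, as the exchange is documented with furan-3-yl alone. Also open, going by these compounds, is how a longer chain such as ethylsulfanyl, a chlorine atom, an amine or a carboxylic acid at this same position would compare with methylsulfanyl and methoxy on the shared core.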